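Trading Fluoro for Hydrogen on a Shared Core

The compounds below may be only part of what the source reports. "The series", "measured", "known", "first", "only" and "open" are said of these compounds alone.

Of the compounds shown here, three of one series have been measured in a physicochemical assay for lipophilicity; on this read-out lower numbers stand for lower lipophilicity and higher numbers for higher lipophilicity. Compound 1 `CN(C)c1ccc(/C=C2\CCC/C(=C\c3ccccc3[N+](=O)[O-])C2=O)cc1` gives 4.86, compound 2 `O=C1/C(=C/c2ccc(F)cc2)CCC/C1=C\c1ccccc1[N+](=O)[O-]` gives 4.86, and compound 3 `CN(C)c1ccc(/C=C2\CCC/C(=C\c3ccc([N+](=O)[O-])cc3)C2=O)cc1` gives 5.08. Compound 2 thus sits level with compound 1 at the digits printed, the two together forming the lowest pair of the three, while compound 3 lies a number 0.22 log units higher from compound 1 to compound 3 (within the scatter), a gap that stays within the scatter.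

Compound 4 `O=C1/C(=C/c2ccccc2)CCC/C1=C\c1ccccc1[N+](=O)[O-]` differs from compound 2 by hydrogen in place of fluoro on an aromatic carbon. The step that bears on this is the one at the same aromatic carbon, where no change at the digits printed from compound 1 to compound 2 (within the scatter). A large change of substituent there left this assay unmoved, and the further step, a number 0.22 log units higher from compound 1 to compound 3 (within the scatter), also stayed within the scatter. A smaller change, fluoro to hydrogen, is therefore expected to shift this assay by no more than the scatter, if anything slightly downward. The expected step of a number 0.14 log units lower from compound 2 to compound 4 (within the scatter) reflects that. Compound 4 is expected to give 4.72, with a range from 4.4 to 5.05.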

Compound 4, partition coefficient: 4.86
Beside the measured number, compound 4's estimate is 0.14 log units below it; the measured number falls inside the stated range.
By their numbers in this assay, from the lowest: compounds 1, 2, 4 and 3 (each within the scatter of the next).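

In this assay, the aromatic carbon para to a large group now has a third occupant, since the change from 4-fluorophenyl to phenyl leaves hydrogen there, and there is no change at the digits printed from compound 2 to compound 4 (within the scatter). Set against dimethylamino at the same carbon, hydrogen likewise gives no change at the digits printed from compound 1 to compound 4 (within the scatter). Among the compounds shown, dimethylamino, fluoro and hydrogen at this carbon thus all lie within the scatter of one another, on the shared core that carries 2-nitrophenyl. No supporting measurement is available to explain this result.

The compounds shown leave open whether a carboxylic acid or a longer alkyl chain at this carbon would stay within the scatter too. They also leave open whether hydrogen or fluoro there would read the same alongside the 4-nitrophenyl of compound 3.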